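Ring size of the amine in the core series

The source may hold more compounds than are shown below. What is called first, only, known or untested is meant among the compounds shown, and "the series" means these compounds.

Compound 1 `FC(F)(F)c1cc(NC[C@H]2CCCN2)c2cn[nH]c2c1` carries a (pyrrolidin-2-yl)methyl amine on the shared core and gives 84% in an assay for inhibition of Tryptophan 2,3-dioxygenase (Homo sapiens), with stated times of 10 min and 60 min, tested at 100 uM; a higher number here means a stronger effect of the compound at the concentration tested, a lower number a weaker effect. Compound 3 `FC(F)(F)c1cccc(CNc2cc(C(F)(F)F)cc3[nH]ncc23)c1` gives 74% in this assay, and compound 2 `O=C(O)CNc1cccc(CNc2cc(C(F)(F)F)cc3[nH]ncc23)c1` gives 65% in this assay. For the measured compounds named here, the one counted step, a number 9 percentage points higher from compound 2 to compound 3 (within the scatter), concerns the benzyl substituent and not the amine. Compound 1 holds the highest of the three numbers; compound 3 lies within the scatter of it, compound 2 lies beyond it.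

Compound 4 `FC(F)(F)c1cc(NC[C@H]2CCCCN2)c2cn[nH]c2c1` differs from compound 1 by piperidin-2-yl in place of pyrrolidin-2-yl on a saturated chain carbon bound to a nitrogen on an aromatic ring. Going by the values given here, no measured step touches this saturated ring, so the only guidance is the spread of the three numbers, all moderate to high. A change of one ring carbon here is not expected to move the read-out beyond the scatter; the expected step of a number 6 percentage points lower from compound 1 to compound 4 (within the scatter) is small and in no firm direction. Compound 4 is therefore estimated at 78%, with a range of 60% to 92%.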

Compound 4, a percentage reported as inhibition, at one concentration (the size of the read-out at that concentration, not a potency): 90%
For compound 4 the middle estimate is 12 percentage points below the measured one; low and high end bracket the measured number.
By their numbers in this assay, from the lowest: compounds 2, 3, 1 and 4 (each within the scatter of the next, the first and the last beyond it).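

The saturated ring now has a measured step of its own: in this assay, piperidin-2-yl in place of pyrrolidin-2-yl gives a number 6 percentage points higher from compound 1 to compound 4 (within the scatter) on the shared core. This place therefore tolerates the six-membered ring with its single ring nitrogen and defined stereocentre, with no shift beyond the scatter and with the read-out still high at the one concentration tested. No available evidence bears on why the two rings read so closely.

Still open, on these data alone, is whether a morpholine ring, an azepane ring or an open-chain amine such as a dimethylaminoethyl group would hold the read-out at this place, and what the opposite configuration at the stereocentre would give. A read-out at one concentration also leaves open whether compound 1 and compound 4 differ in potency.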